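The source may hold more compounds than are shown below. What is called first, only, known or untested is meant among the compounds shown, and "the series" means these compounds.

Working notes on the urea series. For the measured compounds named here, compound 1 `CC(=O)c1ccc(NC(=O)Nc2cc(C)nc3ccccc23)cc1` is the reference point: in an ADME assay on HepG2 cells (Homo sapiens) for cytotoxicity, with a stated time of 72 h (on this read-out lower numbers stand for an effect already at smaller amounts and higher numbers for an effect only at larger amounts of compound), compound 1 gives 19000 nM, the only actual number obtained so far across the three compounds measured. Compound 2 `Cc1cc(NC(=O)Nc2ccc3[nH]cnc3c2)c2ccccc2n1` returns in this assay only a limit, > 25000 nM. Compound 3 `Cc1cc(NC(=O)Nc2cccc(N(C)C)c2)c2ccccc2n1` likewise returns in this assay only a limit, > 25000 nM. Going by the values given here, two of the three results therefore sit at the limit of > 25000 nM in this assay, at which 2 of the 3 values shown sit, and compound 1 is the one member of the set for which the read-out resolved a value at all; no steps between the measured compounds can be stated beyond that.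

Compound 4 `Cc1cc(NC(=O)Nc2ccc(C(=O)O)cc2)c2ccccc2n1` is the next entry to be measured. Relative to compound 1 the change is hydroxy in place of methyl on a carbonyl carbon, the carbonyl attached to the aromatic carbon being kept. With compound 1 already at 19000 nM, the expectation for this assay is a step toward higher numbers, of a size that may or may not clear the usual scatter, expected as a 1.3-fold higher number from compound 1 to compound 4 (0.12 log units; within the scatter). For compound 4 the estimated value is 25000 nM, with the expected range running from 12000 nM to 60000 nM, and a fair chance that the read-out reports only a limit.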

Compound 4, half-maximal effective concentration: > 25000 nM
Compound 4: a limit, no number; the forecaster's own chance of this, stated with the estimate: 60%; the middle value sits exactly at the limit.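

For the compounds shown here, on the carbonyl carbon whose other neighbour is the aromatic carbon, hydroxy in place of methyl (acetyl to carboxy) is the one change that can be read against a resolved number, and in this assay it gives an at least 1.3-fold higher number from compound 1 to compound 4 (0.11 log units; that floor lies within the scatter) as the only step available so far. That step is a floor and not a measured size, so the data do not establish a real difference between the acetyl and carboxy groups at this position, and they place no order on the two compounds. Going by these compounds alone, what the new result adds is that carboxy at this position does not yield a resolved number, leaving compound 1 as the only one of the four compounds with a value that is not a limit: the limit of > 25000 nM in this assay, at which 3 of the 4 values shown sit.

Going by these compounds, whether an amine on the same carbonyl carbon, giving a primary amide, or a methoxy group, giving a methyl ester, would resolve to a number or remain at the limit stays open. Also open, on these data alone, is how far the true value of compound 4 lies beyond its limit, which decides the real size of this step.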